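Bis-sulfonyl piperazine series: ethoxy to methoxy on the core

A few compounds are considered here, and "the series" means these few. Any claim that something is new, unique, unknown or untested is made for them only; others in the source may bear on it.

compound 1 `CCOc1ccc(S(=O)(=O)N2CCN(c3cccc(C)c3)CC2)cc1S(=O)(=O)N1CCN(c2cccc(C)c2)CC1` — 430 nM
compound 2 `COc1ccc(S(=O)(=O)N2CCN(c3ccccc3C)CC2)cc1S(=O)(=O)N1CCN(c2ccccc2C)CC1` — 360 nM

Both were run in a functional assay on blood (Platelet, Oryctolagus cuniculus) for inhibition, read by turbidimetry, with a stated time of 2 min; on this read-out higher numbers stand for weaker inhibition and lower numbers for stronger inhibition. Compound 1 gives 430 nM and stands highest of the two numbers; the nearest, compound 2, gives 360 nM, which lies within the scatter of compound 1, so the two cannot be ranked. Compound 3 `COc1ccc(S(=O)(=O)N2CCN(c3cccc(C)c3)CC2)cc1S(=O)(=O)N1CCN(c2cccc(C)c2)CC1` is not yet measured. It differs from compound 1 by hydrogen in place of methyl on a saturated chain carbon bound to an oxygen on an aromatic ring. Among the compounds with values here, no step between measured compounds covers this change, so the expected step of a 1.1-fold lower number from compound 1 to compound 3 (0.03 log units; within the scatter) is small, none beyond the scatter. Compound 3 is expected to give about 400 nM, within 200 nM to 800 nM.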

Compound 3, half-maximal inhibitory concentration: 710 nM
Compound 3: middle estimate off by 1.8-fold (0.25 log units), on the low side; measured number inside the range.
By their numbers in this assay, from the lowest: compounds 2, 1 and 3 (each within the scatter of the next).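

In this assay the swap of ethoxy for methoxy on the shared core gives a 1.7-fold higher number from compound 1 to compound 3 (0.22 log units; within the scatter) and so provides the first step read at this position. Hydrogen in place of methyl on this saturated chain carbon therefore leaves the two compounds unranked, and the position shows no measurable sensitivity to this one change. Nothing on hand speaks to the reason for either number. Open, as far as these compounds go, is whether a longer chain such as propoxy, or an amine or a carboxylic acid at the end of the chain, would move the number beyond the scatter.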